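From 3-Aminopropyl to Morpholin-4-yl on the Carbonyl

A few compounds are considered here, and "the series" means these few. Any claim that something is new, unique, unknown or untested is made for them only; others in the source may bear on it.

Compound 1 `CCN(CC)S(=O)(=O)c1ccc(NC(=O)c2ccccc2)c2ccccc12`: > 30000 nM
Compound 2 `O=C(Nc1ccc(S(=O)(=O)N2CCCCC2)c2ccccc12)c1ccccc1`: > 30000 nM
Compound 3 `Cc1ccccc1C(=O)Nc1ccc(S(=O)(=O)NC2CCN(C(=O)CCCN)CC2)c2ccccc12`: 1.6 nM

In an assay on L1.2 cells for binding affinity to C-C chemokine receptor type 8 (Homo sapiens) (on this read-out lower numbers stand for stronger inhibition and higher numbers for weaker inhibition), compound 1 reaches only a limit of the assay, > 30000 nM. Compound 2 likewise gives only a limit, > 30000 nM. Among the compounds with values here, the single step between measured compounds, a step that the two limits leave unreadable from compound 1 to compound 2, is therefore of unknown size. Within the data shown here, compound 3 is the one compound with a real number, 1.6 nM, and it stands alone against (the limit of > 30000 nM in this assay, at which 2 of the 3 values shown sit).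

Compound 4 `Cc1ccccc1C(=O)Nc1ccc(S(=O)(=O)NC2CCN(C(=O)N3CCOCC3)CC2)c2ccccc12` differs from compound 3 in one place: morpholin-4-yl in place of 3-aminopropyl on a carbonyl carbon. No measured step touches the group on this carbonyl carbon, so the shown data give no direct guide to the size or direction of the change. The step from compound 1 to compound 2 concerns a different position and is in any case unreadable.

Without a guiding step, the expectation for compound 4 is a modest loss of affinity, read as a 9.4-fold higher number from compound 3 to compound 4 (0.97 log units; beyond the scatter), so that in this assay compound 4 is estimated at 15 nM, within a range from 2 nM to 150 nM.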

Compound 4, inhibition constant: 6.3 nM
Compound 4: the middle estimate sits 2.4-fold (0.38 log units) above what was measured; the measured number falls inside the stated range.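

The group on the carbonyl carbon now has a measured step of its own: in this assay, morpholin-4-yl in place of 3-aminopropyl gives a 3.9-fold higher number from compound 3 to compound 4 (0.60 log units; beyond the scatter). This step lies beyond the usual scatter, so the read-out does respond to this group, but the change is only modest, even though the entering group brings a six-membered non-aromatic ring and has no hydrogen-bond donor, while the leaving group has no ring and one hydrogen-bond donor. In this pair, then, the hydrogen-bond donor of 3-aminopropyl is not required for a real number in the low range, and compound 4 stays clear of the limit reached by other compounds: the limit of > 30000 nM in this assay, at which 2 of the 4 values shown sit.

As far as these compounds go, the ring, the oxygen and the loss of the donor all arrive in this one change, so their separate shares stay unknown, and a cyclohexyl group or a longer aminoalkyl chain on the same carbonyl carbon would be needed to pull them apart. The step between the two compounds at the limit cannot be read, so nothing yet links the group on the sulfonyl sulfur to this result.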